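This account rests on a few compounds, and the source may have more. Where it says the series, first, only, none or still open, it means among the compounds named here.

Working notes on the series. Compound 1 `COc1ccc2ncc(S(=O)(=O)c3ccc(Cl)cc3)c(N3CCC(C)CC3)c2c1` and compound 2 `COc1cccc(S(=O)(=O)c2cnc3ccc(F)cc3c2N2CCC(C)CC2)c1` share one core and have both been run in an assay on isolated protein for displacement of a labelled ligand from metabotropic glutamate receptor 5 (Homo sapiens), with a stated time of 60 min, tested at 1 uM; on this read-out higher numbers stand for more inhibition at the one concentration tested (going by the name of the read-out) and lower numbers for less inhibition. Compound 1 gives 91%, and compound 2 gives 90%; the two numbers lie within the usual scatter of each other, so no order between them can be read. Going by the values given here, no step between measured compounds is available here. Compound 3 `COc1ccc2ncc(S(=O)(=O)c3cc(F)cc(F)c3)c(N3CCC(C)CC3)c2c1` is not yet measured. It differs from compound 1 by 3,5-difluorophenyl in place of 4-chlorophenyl on a sulfonyl sulfur. Among the compounds with values here, with no measured step to lean on, a change of no more than the scatter is expected from compound 1 to compound 3 in this assay, a number 6 percentage points lower from compound 1 to compound 3 (within the scatter). Compound 3 is estimated at 85%, within 65% to 96%.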

Compound 3, a percentage reported as inhibition, at one concentration (the size of the read-out at that concentration, not a potency): 30%
Compound 3: middle estimate off by 55 percentage points, on the high side; measured number below the stated range.
By their numbers in this assay, from the lowest: compound 3; then compounds 2 and 1 (each within the scatter of the next).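

In this assay the series shows a number 61 percentage points lower from compound 1 to compound 3 (beyond the scatter) when 3,5-difluorophenyl replaces 4-chlorophenyl on a sulfonyl sulfur, so this position does not accept every substituted phenyl alike. The shared core alone therefore does not secure the read-out, which the first two compounds could not show. No measurement at hand accounts for the drop. As far as these compounds go, whether the loss follows from removing the chlorine or from adding the two fluorines stays open, as this single step cannot separate them. From the compounds shown here alone, how plain phenyl or cyclohexyl would fare at this position is also open.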